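This account rests on a few compounds, and the source may have more. Where it says the series, first, only, none or still open, it means among the compounds named here.

Compound 3 `O=C1Nc2ccccc2/C1=C/c1ccc(-c2cn(-c3cccc(Cl)c3)nn2)cc1` reads > 20000 nM in a functional assay on HT-29 cells (Homo sapiens) for inhibition, read by CCK-8 assay, with a stated time of 24 h (on this read-out higher numbers stand for weaker inhibition and lower numbers for stronger inhibition), and this is a limit of the assay, not a number. Compound 1 `O=C1Nc2ccccc2/C1=C/c1ccc(-c2cn(-c3ccccc3F)nn2)cc1` gives 10500 nM there, and compound 2 `O=C1Nc2ccccc2/C1=C/c1ccc(-c2cn(-c3ccc(F)cc3)nn2)cc1` gives 17700 nM. Compound 4 `N#Cc1ccccc1-n1cc(-c2ccc(/C=C3\C(=O)Nc4ccccc43)cc2)nn1` carries 2-cyanophenyl in place of 3-chlorophenyl on an aromatic nitrogen. The closest evidence is the swaps on that same nitrogen: a 1.7-fold higher number from compound 1 to compound 2 (0.23 log units; within the scatter), an at least 1.9-fold higher number from compound 1 to compound 3 (0.27 log units; that floor lies within the scatter) and an at least 1.1-fold higher number from compound 2 to compound 3 (0.05 log units; that floor lies within the scatter), each within the scatter or with a floor within it. No step beyond the scatter is therefore expected in this assay, though a measured number would be expected on the lower side of compound 3, with its limit of > 20000 nM. The expected step is an at least 1.4-fold lower number from compound 3 to compound 4 (0.15 log units; that floor lies within the scatter). For compound 4 the estimated value is 14000 nM, with a range of 7000 nM to 25000 nM.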

Compound 4, half-maximal inhibitory concentration: 14400 nM
Estimate against measurement, compound 4: 1.0-fold (0.01 log units) below; low and high end bracket the measured number.
By their numbers in this assay, from the lowest: compounds 1, 4 and 2 (each within the scatter of the next). At a limit, above all of these: compound 3.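

Because compound 3 in this assay stands at a limit, not a number, the change to 2-cyanophenyl reads only as an at least 1.3-fold lower number from compound 3 to compound 4 (0.14 log units; that floor lies within the scatter): the limit of > 20000 nM in this assay, at which 1 of the 4 values shown sits.

Against the two fluorophenyl compounds, the steps are a 1.2-fold lower number from compound 2 to compound 4 (0.09 log units; within the scatter) and a 1.4-fold higher number from compound 1 to compound 4 (0.14 log units; within the scatter). A nitrile, with its hydrogen-bond acceptor, therefore fits on this aromatic nitrogen's phenyl without a step beyond the scatter from either fluoro compound.

As far as these compounds go, whether any group at this position moves the number beyond the scatter stays open. An amine or a carboxylic acid on the phenyl, or a longer chain in its place, would test that.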